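Acetyl in Place of 2-Methoxyethyl on a Diaziridinyl Quinone

This account rests on a few compounds, and the source may have more. Where it says the series, first, only, none or still open, it means among the compounds named here.

Measured compounds:
compound 1 `COCCC1=C(N2CC2)C(=O)C(C)=C(N2CC2)C1=O` — 5.19
compound 2 `CC1=C(N2CC2)C(=O)C(CCCc2ccccc2)=C(N2CC2)C1=O` — 3.93

Of the compounds shown here, two on this shared core have been tested in a functional assay on L1210 cells (Mus musculus), with a stated time of 1 days; on this read-out higher numbers stand for higher potency (the scale is a negative logarithm) and lower numbers for lower potency. Going by the values given here, compound 1 stands highest of the two, and its only neighbour is compound 2, with a number 1.26 log units lower from compound 1 to compound 2 (beyond the scatter). That is a large loss for a benzyl in place of methoxy on a saturated chain carbon.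

Compound 3 `CC(=O)C1=C(N2CC2)C(=O)C(C)=C(N2CC2)C1=O` has not been measured. It differs from compound 1 by acetyl in place of 2-methoxyethyl on a double-bonded ring carbon. Among the compounds with values here, the single measured step swaps a group at the end of a chain, while here the whole 2-methoxyethyl chain gives way to an acetyl directly on the ring carbon, so that step is only a loose guide. Without a closer comparison, a modest change in either direction is expected, a number 0.19 log units lower from compound 1 to compound 3 (within the scatter), leaving compound 3 near compound 1. The estimate for compound 3 is 5, with a range from 4.2 to 5.8.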

Compound 3, logarithm of the reciprocal of the active concentration, log(1/C): 3.94
The estimate for compound 3 lay 1.06 log units above the measured number, outside the stated range (below it).
By their numbers in this assay, from the lowest: compounds 2 and 3 (each within the scatter of the next); then compound 1.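

In this assay, the double-bonded ring carbon that carries the 2-methoxyethyl group in compound 1 proves sensitive to a change of group: acetyl in its place gives a number 1.25 log units lower from compound 1 to compound 3 (beyond the scatter). Both groups are uncharged and without a ring, and they have the same counts of hydrogen-bond donors and acceptors, so those counts do not separate them, yet the step is large. No measurement at hand offers a reason for this loss.

The compounds shown leave open whether the loss goes with the acetyl carbonyl sitting directly on the ring carbon or with the disappearance of the 2-methoxyethyl chain. A 2-oxopropyl group or a plain ethyl group on this ring carbon would help separate these two readings.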